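From 3,5-dimethylphenyl to 4-nitrophenyl in compound 1

The compounds below may be only part of what the source reports. "The series", "measured", "known", "first", "only" and "open" are said of these compounds alone.

Compound 1 `Cc1cc(C)cc(NC(=O)NCCNS(=O)(=O)c2ccc(-c3ccccc3Oc3ccc([N+](=O)[O-])c([N+](=O)[O-])c3)s2)c1` gives 12000 nM
Compound 2 `COc1ccc(Oc2ccc([N+](=O)[O-])cc2-c2ccsc2S(=O)(=O)N2CCN(C(=S)Nc3ccc(Cl)cc3)CC2)cc1OC` gives > 50000 nM (a limit, not a number)
Compound 3 `O=S(=O)(NCCNC(=S)Nc1cccc(Cl)c1)c1ccc(-c2ccccc2OCc2ccccc2)s1` gives 8400 nM

In a functional assay on HeLa cells (Homo sapiens) for inhibition, read by CCK-8 assay, with a stated time of 48 h (on this read-out higher numbers stand for weaker inhibition and lower numbers for stronger inhibition), compound 1 at 12000 nM and compound 3 at 8400 nM lie within the usual scatter of each other, so no order can be drawn between them. Among the measured compounds shown here, these are the only two true numbers in the set. Compound 2 is reported only as a limit of the read-out, at > 50000 nM and not as a number.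

The next compound to be tested is compound 4 `O=C(NCCNS(=O)(=O)c1ccc(-c2ccccc2Oc2ccc([N+](=O)[O-])c([N+](=O)[O-])c2)s1)Nc1ccc([N+](=O)[O-])cc1`, which has not yet been measured. It differs from compound 1 in one place (4-nitrophenyl in place of 3,5-dimethylphenyl on an amide-type nitrogen), with 4-nitrophenyl in place of 3,5-dimethylphenyl on an amide-type nitrogen. For the measured compounds named here, no measured pair of compounds differs in one place only, so the size of this change has no direct precedent here. No step beyond the scatter is expected in this assay, and no direction can be argued with confidence. The expectation therefore stays close to compound 1 at 12000 nM with a wide margin on either side. The estimate amounts to an expected 1.2-fold lower number from compound 1 to compound 4 (0.08 log units; within the scatter) within the scatter. Compound 4 is estimated at 10000 nM with an expected range from 3500 nM to 30000 nM on this read-out.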

Compound 4, half-maximal inhibitory concentration: > 20000 nM
Compound 4: only a limit was reported; the forecaster's own chance of this, stated with the estimate: 10%; middle value at least 2.0-fold (0.30 log units) away from the limit.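

In this assay compound 4 gives > 20000 nM, which is a limit of the read-out and not a number: the limit of > 20000 nM in this assay, at which 1 of the 4 values shown sits. Read against its one-place neighbour, the result is an at least 1.6-fold higher number from compound 1 to compound 4 (0.22 log units; that floor lies within the scatter), and this is the first comparison in the set in which a single place changes, here the aryl group on the amide-type nitrogen whose other neighbour is the carbonyl carbon. It gives no sign that 4-nitrophenyl at this place brings stronger inhibition than 3,5-dimethylphenyl, yet the floor of the step does not establish weaker inhibition either, so the pair fixes only a lower bound on the change and not its size.

On these data alone, how far the true value of compound 4 lies from that of compound 1 remains open, and compounds 2 and 3 differ from both in more than one place, so they cannot settle it. Also open, as far as these compounds go, is what a plain phenyl, a 4-aminophenyl or a cyclohexyl group on the same nitrogen would give, and whether any group at this place moves the read-out beyond the usual scatter.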